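Urea series: permeability notes around compound 2 and compound 3

A few compounds are considered here, and "the series" means these few. Any claim that something is new, unique, unknown or untested is made for them only; others in the source may bear on it.

Measured so far in an ADME assay on LLC-PK1 cells (Sus scrofa) for permeability; on this read-out lower numbers stand for lower permeability and higher numbers for higher permeability:
compound 1 `COc1ccccc1C(=O)NC(=S)Nc1ccc(N2CCCCC2)c(Cl)c1`: 1.8 10^-6 cm/s
compound 2 `COc1ccccc1C(=O)NC(=O)Nc1ccc(-c2nccs2)c(C(F)(F)F)c1`: 12 10^-6 cm/s

Compound 2 stands at the highest of the two numbers in this assay; its nearest neighbour is compound 1, whose number is lower by a gap that lies beyond the scatter. Compound 3 `COc1ccccc1C(=O)NC(=O)Nc1ccc(OCC(F)(F)F)c(C(F)(F)F)c1` has not yet been measured in this assay. It differs from compound 2 in one place: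

2,2,2-trifluoroethoxy in place of 1,3-thiazol-2-yl on an aromatic carbon

Going by the values given here, no measured pair in this set tracks that exchange, so there is no step to calibrate against. The expectation is a small step in this assay, at most on the edge of the scatter, if anything toward a lower number. Compound 3 is estimated at 9 10^-6 cm/s, with a range from 4 10^-6 cm/s to 20 10^-6 cm/s. This estimate means a step of a 1.3-fold lower number from compound 2 to compound 3 (0.12 log units; within the scatter).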

Compound 3, apparent permeability in the LLC-PK1 assay: < 1 10^-6 cm/s
Compound 3 gave a limit, no number (the forecaster's own chance of this, stated with the estimate: 5%); at least 9.0-fold (0.95 log units) between middle value and limit.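

Going by these compounds alone, the position para to a large group and ortho to a trifluoromethyl group proves sensitive to this exchange: in the LLC-PK1 assay, 2,2,2-trifluoroethoxy in place of 1,3-thiazol-2-yl gives an at least 12-fold lower number from compound 2 to compound 3 (1.07 log units; beyond the scatter), the only step available for this position. Going by these compounds, the read-out for compound 3 is a limit of the assay and not a number, so the full size of the step stays unknown. In a physicochemical assay for solubility, in simulated intestinal fluid (on this read-out lower numbers stand for lower solubility and higher numbers for higher solubility), compound 2 gives 12 ug/mL and compound 3 gives 2.2 ug/mL.

Whether the two read-outs move together cannot be told from a single pair. Also open, on these data alone, is whether the ring that leaves or the chain that enters carries the step; an ethoxy group or a pyridine ring on the same aromatic carbon would help separate the two.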